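Trifluoromethyl added to compound 2

The compounds below may be only part of what the source reports. "The series", "measured", "known", "first", "only" and "open" are said of these compounds alone.

Compound 2 (`C=CCCCCOc1ncc(-c2ccccc2OC)n1C`) holds the lower of the two numbers in a functional assay on A549 cells (Homo sapiens) for inhibition, read by colorimetric assay and MTT assay, with a stated time of 72 h (on this read-out higher numbers stand for weaker inhibition and lower numbers for stronger inhibition), at 5000 nM while compound 1 (`CCCCOc1ncc(-c2ccccc2OC)n1C`) stands at 87000 nM on the same read-out. Among the compounds with values here, the only measured step is a 17-fold lower number from compound 1 to compound 2 (1.24 log units; beyond the scatter) and it is a change on the chain: vinyl in place of hydrogen on a saturated chain carbon.

Compound 3 (`C=CCCCCOc1ncc(-c2cc(C(F)(F)F)ccc2OC)n1C`) departs from compound 2 elsewhere, by trifluoromethyl in place of hydrogen on an aromatic carbon as trifluoromethyl in place of hydrogen on an aromatic carbon, meta to a large group and para to a methoxy group. Within the data shown here, no measured step covers a change at that aromatic carbon. The chain step therefore bears on it only indirectly, showing that a single change can move the number a long way in this pair.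

Among the measured compounds shown here, with no direct precedent, a small expected step in this assay is the working assumption, leaning slightly towards a lower number and within the scatter. The estimated step is a 1.7-fold lower number from compound 2 to compound 3 (0.22 log units; within the scatter) with a wide margin in either direction. For compound 3 the estimated value is 3000 nM with an expected range from 800 nM to 12000 nM on present evidence.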

Compound 3, half-maximal inhibitory concentration: 62000 nM
Compound 3: the middle estimate sits 21-fold (1.32 log units) below what was measured; measured number outside the range, above it.
By their numbers in this assay, from the lowest: compound 2; then compounds 3 and 1 (each within the scatter of the next).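

In this assay, the aromatic carbon para to a methoxy group proves sensitive to substitution: trifluoromethyl in place of hydrogen there gives a 12-fold higher number from compound 2 to compound 3 (1.09 log units; beyond the scatter). Within the data shown here, this is the first measured step on the aromatic ring, and it runs towards weaker inhibition, the opposite direction to the change on the chain, which gave a 17-fold lower number from compound 1 to compound 2 (1.24 log units; beyond the scatter). No measurement of any property of these compounds bears on this step, so the data offer no explanation for it.

The compounds shown leave open whether the weaker inhibition belongs to trifluoromethyl specifically or to any group at this aromatic carbon; values for methyl or fluorine at the same carbon would separate those two readings. Also open, from the compounds shown here alone, is whether the step depends on the chain, since it is read only with the chain of compound 2, and the same trifluoromethyl change on the chain of compound 1 would show whether the two changes act independently.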